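Geometry of the exocyclic double bond in compound 4

The compounds below may be only part of what the source reports. "The series", "measured", "known", "first", "only" and "open" are said of these compounds alone.

Measured compounds:
compound 1, `O=C1Nc2ccc(F)cc2/C1=C\c1cccc(OCc2cn(Cc3ccccc3)nn2)c1`, > 50000 nM
compound 2, `O=C1Nc2ccc([N+](=O)[O-])cc2/C1=C\c1cccc(OCc2cn(Cc3ccccc3)nn2)c1`, > 50000 nM
compound 3, `CC(=O)c1ccc2c(c1)/C(=C/c1cccc(OCc3cn(Cc4ccccc4)nn3)c1)C(=O)N2`, 36300 nM

In a functional assay on A549 cells (Homo sapiens) for inhibition, read by MTT assay, with a stated time of 48 h (on this read-out lower numbers stand for stronger inhibition and higher numbers for weaker inhibition), compound 1 reaches only a limit, > 50000 nM. Compound 2 likewise gives a limit in this assay, > 50000 nM. The step from compound 1 to compound 2, nitro in place of fluoro on an aromatic carbon, is therefore a step that the two limits leave unreadable from compound 1 to compound 2; the two limits leave its size unreadable, as the limit of > 50000 nM in this assay, at which 2 of the 3 values shown sit, makes clear. Compound 3 is the only one of the three with a number in this assay, 36300 nM, and it stands as a weak inhibitor.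

Compound 4, `CC(=O)c1ccc2c(c1)/C(=C\c1cccc(OCc3cn(Cc4ccccc4)nn3)c1)C(=O)N2`, differs from compound 3 only in drawn configuration: the two compounds have the same atoms and bonds and differ only in configuration as drawn: 1 of 1 stereo elements differ; a double bond is drawn Z in compound 3 and E in compound 4. Among the measured compounds shown here, none of the measured steps changes the geometry of this double bond, so no measured step bears on it, and the one readable value gives no direction. Compound 4 is expected to sit near compound 3, a step of a 1.1-fold higher number from compound 3 to compound 4 (0.04 log units; within the scatter) with a wide range around 40000 nM, from 12000 nM to 50000 nM.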

Compound 4, half-maximal inhibitory concentration: > 50000 nM
Compound 4 gave a limit, no number; the forecaster's own chance of this, stated with the estimate: 40%; middle value at least 1.2-fold (0.09 log units) away from the limit.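

In this assay compound 4 reaches only a limit, > 50000 nM. Among the compounds shown here, the geometry of the exocyclic double bond, which no earlier step touched, now has a reading of its own, an at least 1.3-fold higher number from compound 3 to compound 4 (0.13 log units; that floor lies within the scatter), so the shift from Z to E as drawn does not lower the number, and its floor does not set the two isomers apart beyond the scatter. Nothing else enters this comparison: the fact that compounds 3 and 4 differ only in the configuration as drawn.

Going by these compounds, the steps to compound 4 from compound 1 and compound 2 cannot be read, and the full size of the geometry step stays open because the values stop at a ceiling: the limit of > 50000 nM in this assay, at which 3 of the 4 values shown sit. Also open, on these data alone, is whether an amine or a carboxylic acid in place of acetyl on the aromatic carbon would give a number in either geometry.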